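The source may hold more compounds than are shown below. What is called first, only, known or untested is meant among the compounds shown, and "the series" means these compounds.

Among the measured compounds shown here, in an ADME assay on L929 cells (Mus musculus) for cytotoxicity, read by resazurin assay, with a stated time of 72 h (on this read-out lower numbers stand for stronger inhibition and higher numbers for weaker inhibition), compound 2 `Cc1cccc(C(=O)/C=C/c2ccc3c(c2)B(O)OC3)c1` gives 8.56 ug/mL, the only exact number among the three compounds measured. Compound 1 `O=C(/C=C/c1ccc2c(c1)B(O)OC2)c1ccc(OCc2ccccc2)cc1` is reported only as a limit, > 10 ug/mL. Compound 3 `Cc1ccc(C(=O)/C=C/c2ccc3c(c2)B(O)OC3)cc1C` is also reported only as a limit, > 10 ug/mL. The next structure is compound 4 `Nc1ccc(C(=O)/C=C/c2ccc3c(c2)B(O)OC3)cc1`, with 4-aminophenyl in place of 3-methylphenyl on a carbonyl carbon. For the measured compounds named here, no measured step makes this exact change. The nearest one, methyl in place of hydrogen on an aromatic carbon, is an at least 1.1-fold higher number from compound 2 to compound 3 (0.06 log units; that floor lies within the scatter), so no shift beyond the scatter is expected in this assay. The expected change is a 1.1-fold lower number from compound 2 to compound 4 (0.03 log units; within the scatter). The estimated value for compound 4 is 8 ug/mL, with an expected range from 3 ug/mL to 20 ug/mL.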

Compound 4, half-maximal inhibitory concentration: > 10 ug/mL
Compound 4: a limit, no number; the forecaster's own chance of this, stated with the estimate: 40%; at least 1.2-fold (0.09 log units) between middle value and limit.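

Replacing the 3-methylphenyl on the carbonyl carbon with 4-aminophenyl, which brings in a hydrogen-bond donor and acceptor, gives an at least 1.1-fold higher number from compound 2 to compound 4 (0.06 log units; that floor lies within the scatter) in this assay. Compound 4 is reported only as a limit, so this change of ring, like the added methyl before it, shows no shift beyond the scatter, and the step that links it with compound 1 cannot be read. A ring carrying nitrogen at this place therefore ends at the same limit as most of the series: the limit of > 10 ug/mL in this assay, at which 3 of the 4 values shown sit.

From the compounds shown here alone, how far the true value of compound 4 lies past that limit stays open. Also open, going by these compounds, is whether a carboxylic acid or a longer chain on this ring would move the number clearly away from that of compound 2.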